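A piperidin-1-yl swap at the assay limit

The source may report more compounds than this note shows. Statements on the series, on what has been measured and on what is new or still open speak of the compounds shown alone.

In a functional assay on ECa-109 cells (Homo sapiens) for antiproliferative activity, read by MTT assay, with a stated time of 48 h (a lower number here means a stronger inhibitor, a higher number a weaker inhibitor), compound 3 `CN1CCN(CCCn2nc(C3=C(c4cn(C)c5ccccc45)C(=O)NC3=O)c3cccnc32)CC1` gives > 100000 nM, which is a limit and not a number. Compound 2 `Cn1cc(C2=C(c3nn(CCCn4ccnc4)c4ncccc34)C(=O)NC2=O)c2ccccc21` likewise gives only a limit, > 100000 nM. Together they account for (the limit of > 100000 nM in this assay, at which 2 of the 3 values shown sit). Within the data shown here, the one measured step that bears on the change is a step that the two limits leave unreadable from compound 2 to compound 3.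

Compound 4 `Cn1cc(C2=C(c3nn(CCCN4CCCCC4)c4ncccc34)C(=O)NC2=O)c2ccccc21` has piperidin-1-yl in place of 4-methylpiperazin-1-yl on a saturated chain carbon, three bonds along the chain from an aromatic nitrogen. Compound 1 `Cn1cc(C2=C(c3nn(CCCN4CCCCC4)c4ncccc34)C(=O)N(c3cccc4ccccc34)C2=O)c2ccccc21`, which also carries piperidin-1-yl but not the same core, gives 1830 nM, and this offers only a weak hint of a gain. The expected move is therefore modest, toward stronger inhibition, as an at least 2.5-fold lower number from compound 3 to compound 4 (0.39 log units; beyond the scatter), and another limit remains quite possible. Compound 4 is estimated at 40000 nM, within an expected range of 8000 nM to 120000 nM.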

Compound 4, half-maximal inhibitory concentration: 42300 nM
The estimate for compound 4 lay 1.1-fold (0.02 log units) below the measured number, and the stated range covers the measured number.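

In this assay, compound 4 is the first compound shown with the amide hydrogen to give a number rather than a limit, while compound 2 and compound 3 stay at that limit: the limit of > 100000 nM in this assay, at which 2 of the 4 values shown sit. Piperidin-1-yl on the chain therefore gives an at least 2.3-fold lower number from compound 3 to compound 4 (0.37 log units; beyond the scatter) and likewise an at least 2.3-fold lower number from compound 2 to compound 4 (0.37 log units; beyond the scatter), both real changes of unknown full size. Hydrogen in place of naphthalen-1-yl on the amide-type nitrogen gives a 23-fold higher number from compound 1 to compound 4 (1.36 log units; beyond the scatter), the large step here.

Going by these compounds, it remains open whether morpholin-4-yl on the same chain would match piperidin-1-yl. Also open, on these data alone, is whether a phenyl or methyl on the amide-type nitrogen would recover part of that step.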